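The compounds below may be only part of what the source reports. "The series", "measured", "known", "first", "only" and "open" are said of these compounds alone.

In a functional assay on LoVo cells (Homo sapiens) for inhibition, read by colorimetric assay and MTT assay, with a stated time of 72 h (a lower number here means a stronger inhibitor, a higher number a weaker inhibitor), compound 1 (`C=CCCCCOc1ccccc1-c1cnc(OCCC=C)n1C`) gives 12000 nM and is the strongest of the three measured compounds. Two relatives show higher numbers: compound 2 (`C=CCCCCOc1ccc(OC)cc1-c1cnc(OCCC=C)n1C`) at 33000 nM and compound 3 (`C=CCCCCOc1ccc(F)cc1-c1cnc(OCCC=C)n1C`) at 38000 nM on the same scale.

Compound 4 (`C=CCCCCOc1ccccc1-c1cnc(OCCCC=C)n1C`) has not been measured yet. Its structure departs from compound 1 in one chain: allyl in place of vinyl on a saturated chain carbon, two bonds along the chain from an oxygen on an aromatic ring and the same change reads as (but-3-en-1-yl)oxy to (pent-4-en-1-yl)oxy.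

Among the compounds with values here, no measured step touches this chain, so the evidence is only indirect. On an aromatic carbon, methoxy gave a 2.8-fold higher number from compound 1 to compound 2 (0.44 log units; beyond the scatter) and fluoro gave a 3.2-fold higher number from compound 1 to compound 3 (0.50 log units; beyond the scatter) while swapping those two gave a 1.2-fold higher number from compound 2 to compound 3 (0.06 log units; within the scatter) in turn. These steps are modest at most, and the new change is a small one on a different part of the molecule. No step beyond the scatter is therefore expected in this assay for this change.

The expected result is a 1.2-fold higher number from compound 1 to compound 4 (0.07 log units; within the scatter) and no larger. Compound 4 is estimated at 14000 nM with an expected range from 6000 nM to 35000 nM overall.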

Compound 4, half-maximal inhibitory concentration: 4000 nM
For compound 4 the middle estimate is 3.5-fold (0.54 log units) above the measured one; the measured number lies below the stated range.
By their numbers in this assay, from the lowest: compound 4; then compound 1; then compounds 2 and 3 (each within the scatter of the next).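

Lengthening the (but-3-en-1-yl)oxy chain to (pent-4-en-1-yl)oxy gives a 3.0-fold lower number from compound 1 to compound 4 (0.48 log units; beyond the scatter) in this assay and so shows that this chain, untouched by the earlier steps, can shift the number beyond the scatter. Methoxy and fluoro on the aromatic carbon each raised the number from compound 1, which makes this the first single change shown to lower it. Nothing available here accounts for the size or direction of this step.

From the compounds shown here alone, whether a longer chain such as hex-5-en-1-yl would lower the number further, or a saturated pentyl chain would do the same without the double bond, remains open. Going by these compounds, it is also open whether the (pent-4-en-1-yl)oxy chain would lower the number when methoxy or fluoro is present on the aromatic carbon.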